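From compound 1 to compound 4: a charged group

The source may report more compounds than this note shows. Statements on the series, on what has been measured and on what is new or still open speak of the compounds shown alone.

In a functional assay (muscle tissue) with Cavia porcellus as the target (on this read-out higher numbers stand for an effect only at larger amounts of compound and lower numbers for an effect already at smaller amounts), compound 1 `COC(=O)C1=C(C)N=C(C)/C(=C(\O)OC)C1c1cccc(N(C)C)c1` gives 891 nM. Compound 3 `COC(=O)C1=C(C)N=C(C)/C(=C(\O)OC)C1c1cc([N+](=O)[O-])ccc1O` gives 100 nM, and compound 2 `COC(=O)C1=C(C)N=C(C)/C(=C(\O)OC)C1c1cccc(Cl)c1Cl` gives 19.1 nM. Compound 1 therefore has the highest number of the three, and both gaps lie beyond the usual scatter. The three compounds share a core but differ in more than one place on the aromatic ring, so no single change can be read from them.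

Compound 4 `COC(=O)C1=C(C)N=C(C)/C(=C(\O)OC)C1c1cccc([N+](C)(C)C)c1` keeps the core of compound 1 and alters one group: a group of 4 heavy atoms (3 carbon, 1 nitrogen; no ring) in place of a group of 3 heavy atoms (2 carbon, 1 nitrogen; no ring), on an aromatic carbon. The dimethylamino group leaves, and the group that enters carries a net charge of +1. Within the data shown here, none of the measured compounds has a net charge, so the data offer no direct guide and the expectation below is a judgement with a wide range.

A shift towards a higher number, beyond the scatter, is expected in this assay, with an estimated step of a 6.7-fold higher number from compound 1 to compound 4 (0.83 log units; beyond the scatter). The estimate for compound 4 is 6000 nM, with an expected range of 1200 nM to 30000 nM.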

Compound 4, half-maximal effective concentration: 50100 nM
Estimate against measurement, compound 4: 8.4-fold (0.92 log units) below, outside the stated range (above it).
By their numbers in this assay, from the lowest: compound 2; then compound 3; then compound 1; then compound 4.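

In this assay, among these compounds, exchanging dimethylamino for the group with net charge +1 on this aromatic carbon gives a 56-fold higher number from compound 1 to compound 4 (1.75 log units; beyond the scatter), the first comparison that differs in one place. Among the compounds shown here, the read-out therefore responds strongly to this exchange at this position, which the earlier compounds, differing in more than one place, could not show. The exchange alters net charge, heavy-atom count and hydrogen-bond acceptor count together, and no measurement shown bears on which of these accounts for the step.

Open, on these data alone, is how the read-out would respond at this position to a tert-butyl group, an uncharged carbon-only group, or to a carboxylic acid. Also open, as far as these compounds go, is whether the same exchange elsewhere on the aromatic ring would give a step of similar size.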